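This account rests on a few compounds, and the source may have more. Where it says the series, first, only, none or still open, it means among the compounds named here.

Compound 2 `COc1ccccc1N1CCN(CCC(Oc2ccc(C(=O)Nc3ccccc3OCCCC(=O)O)cc2)c2ccccc2)CC1` stands at the low end of the two numbers available: in an assay on Prostate gland (Oryctolagus cuniculus) for inhibition of Adrenergic receptor alpha-1 (Homo sapiens) (on this read-out lower numbers stand for tighter binding and higher numbers for weaker binding), compound 2 gives 25.1 nM. Its close relative compound 1 `CCc1ccc(C(CCN2CCN(c3ccccc3OC)CC2)Oc2ccc(NC(=O)c3ccccc3OCCCC(=O)O)cc2)cc1` gives 200 nM in this assay, a clearly higher number. Compound 3 `COc1ccccc1N1CCN(CCC(Oc2ccc(C(=O)Nc3ccccc3OCCCC(=O)O)cc2)c2ccc(Br)cc2)CC1` differs from compound 2 by bromo in place of hydrogen on an aromatic carbon. Within the data shown here, no measured step covers this exact change, so the expectation rests on compound 1, whose value of 200 nM shows that a substituted ring here can carry a higher number. A modest rise, beyond the scatter, is expected, a 3.2-fold higher number from compound 2 to compound 3 (0.50 log units; beyond the scatter). Compound 3 is estimated at 80 nM, within 25 nM to 250 nM.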

Compound 3, dissociation constant: 100 nM
Beside the measured number, compound 3's estimate is 1.3-fold (0.10 log units) below it, within the range that was stated.
By their numbers in this assay, from the lowest: compound 2; then compounds 3 and 1 (each within the scatter of the next).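

Going from phenyl to 4-bromophenyl in this assay gives a 4.0-fold higher number from compound 2 to compound 3 (0.60 log units; beyond the scatter) and is the first measured step here that changes one place only. It shows that this ring position, para to a large group, responds to substitution: a single bromine atom in place of hydrogen moves the number upward, beyond the scatter. No measurement available here explains this rise. On these data alone, whether fluoro, methoxy or an amine at this same place would raise the number as bromo does stays open, as does the result of bromo elsewhere on this ring.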